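The source may hold more compounds than are shown below. What is called first, only, known or untested is meant among the compounds shown, and "the series" means these compounds.

Compound 1 `COc1ccc(C(=O)/C=C/c2cc(-c3cc(OC)c(OC)c(OC)c3)n[nH]2)cc1OC`: -95%
Compound 2 `COc1ccc(C(=O)/C=C/c2cc(-c3cc(OC)c(OC)c(OC)c3)n[nH]2)cc1`: -83%

In a functional assay on ACHN cells (Homo sapiens) for cytotoxicity, read by sulforhodamine B assay, with a stated time of 48 h, tested at 10 uM (a higher number here means a weaker effect of the compound at the concentration tested, a lower number a stronger effect), compound 1 gives -95%, the lowest of the two numbers; compound 2 gives -83%. Within the data shown here, the only step between them is a number 12 percentage points higher from compound 1 to compound 2 (beyond the scatter), a hydrogen in place of methoxy on an aromatic carbon, which made the effect weaker. Compound 3 `COc1cc(C(=O)/C=C/c2cc(-c3cc(OC)c(OC)c(OC)c3)n[nH]2)cc(OC)c1OC` differs from compound 1 by methoxy in place of hydrogen on an aromatic carbon. That step bears on it in reverse: removing a methoxy cost a modest amount, and compound 1 already stands near the strongest level seen, so no step beyond the scatter is expected, a number 1 percentage points higher from compound 1 to compound 3 (within the scatter). Compound 3 is therefore estimated at -94%, between -104% and -82%.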

Compound 3, a percentage reported as activity, at one concentration (the size of the read-out at that concentration, not a potency): -97%
For compound 3 the middle estimate is 3 percentage points above the measured one; the measured number falls inside the stated range.
By their numbers in this assay, from the lowest: compounds 3 and 1 (each within the scatter of the next); then compound 2.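

In this assay, a methoxy can take the place of hydrogen on the aromatic carbon ortho to a methoxy group and meta to a large group with no step beyond the scatter: a number 2 percentage points lower from compound 1 to compound 3 (within the scatter). The ring accepts a further methoxy here, whereas the loss of a methoxy at the other place carried a cost: a number 12 percentage points higher from compound 1 to compound 2 (beyond the scatter). Nothing measured here explains this difference between the two places. Still open, on these data alone, is whether an amine or a longer chain such as ethoxy at this position would hold the same level, and whether a read-out at one concentration hides differences that would show at other concentrations.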